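A Smaller Group in Place of Phenoxy

A few compounds are considered here, and "the series" means these few. Any claim that something is new, unique, unknown or untested is made for them only; others in the source may bear on it.

Of the compounds shown here, two have been tested so far in a functional assay on M14 cells (Homo sapiens) for cytotoxicity, read by sulforhodamine B assay, with a stated time of 48 h, tested at 0.001 uM; a higher number here means a weaker effect of the compound at the concentration tested, a lower number a stronger effect. Compound 1 `COc1cc(C)cc(-c2nn(CC#N)cc2-c2ccc(-c3cccc(C(C)=O)c3)nc2)c1` gives 94% in this assay. Compound 2 `Cc1cc(O)cc(-c2nn(CC#N)cc2-c2ccnc(-c3ccc(Oc4ccccc4)cc3)c2)c1` gives 95% in this assay. Compound 2 has the higher of the two numbers, but the gap to compound 1 lies within the scatter, so the two values cannot be told apart. Both numbers are high, which at this concentration points to a weak effect of either compound.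

Compound 3 `Cc1cc(O)cc(-c2nn(CC#N)cc2-c2ccnc(-c3ccc(N(C)C)cc3)c2)c1` has not been measured. It differs from compound 2 in one place: dimethylamino in place of phenoxy on an aromatic carbon. The new group sits on an aromatic carbon of a six-membered aromatic ring of carbon only, para to a large group, where the phenoxy group stood before.

For the measured compounds named here, no step between two measured compounds is available to guide a forecast, so the expectation rests on the two values alone. Since compound 1 and compound 2 show the same weak effect despite different groups at the outer position, the step of a number 2 percentage points lower from compound 2 to compound 3 (within the scatter) is expected to stay within the scatter, in no particular direction. Compound 3 is therefore estimated at 93%, with a likely range from 80% to 102%.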

Compound 3, a percentage reported as activity, at one concentration (the size of the read-out at that concentration, not a potency): 96%
Compound 3: the middle estimate sits 3 percentage points below what was measured; the measured number falls inside the stated range.
By their numbers in this assay, from the lowest: compounds 1, 2 and 3 (each within the scatter of the next).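

For the compounds shown here, putting dimethylamino in place of phenoxy on this aromatic carbon gives a number 1 percentage points higher from compound 2 to compound 3 (within the scatter) in this assay and is the first change seen here that alters a single place in the molecule. The entering group has 3 heavy atoms and no ring, against 7 heavy atoms and a six-membered aromatic ring in phenoxy, yet this large difference in the group leaves the two numbers indistinguishable, and both still point to a weak effect at this one concentration. Nothing measured here bears on why the two numbers match.

With every number this high, the compounds shown do not reveal whether any group at this position can produce a stronger effect, and a read-out at one very low concentration says nothing about what the same compounds would do at higher ones. A primary amine, a methoxy group or a carboxylic acid in the same place would test whether this position can shift the number at all, or whether the compounds remain as weak as compound 2 and compound 3 whatever stands there.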